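A few compounds are considered here, and "the series" means these few. Any claim that something is new, unique, unknown or untested is made for them only; others in the source may bear on it.

In an assay on membranes from Cerebral cortex for displacement of a labelled ligand from Neuronal acetylcholine receptor; alpha4/beta2 (Rattus norvegicus), with a stated time of 30 min (a higher number here means a weaker inhibitor, a lower number a stronger inhibitor), compound 1 `CN1CCC[C@H]1COc1cccc(C#CCCCCO)c1` gives 4400 nM, and compound 2 `CN1CCC[C@H]1COc1cc(O)cc(C#CCCCCO)c1` gives 23.7 nM, the lowest of the two numbers; the change is a 190-fold lower number from compound 1 to compound 2 (2.27 log units; beyond the scatter). Compound 3 `CN1CCC[C@H]1COc1cc(O)cc(-c2ccccc2)c1` differs from compound 2 by phenyl in place of 6-hydroxyhex-1-yn-1-yl on an aromatic carbon. Among the measured compounds shown here, the only measured step concerns a different change, so nothing measured bears directly on this swap. Losing the 6-hydroxyhex-1-yn-1-yl group is expected to raise the number moderately, an estimated 4.2-fold higher number from compound 2 to compound 3 (0.63 log units; beyond the scatter) in this assay. Compound 3 is therefore expected at about 100 nM, within a range from 15 nM to 700 nM.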

Compound 3, inhibition constant: 528 nM
Compound 3: the middle estimate sits 5.3-fold (0.72 log units) below what was measured; measured number inside the range.
By their numbers in this assay, from the lowest: compound 2; then compound 3; then compound 1.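

The earlier step concerned only the hydroxy group on the ring; this one shows that the other substituent at this position also matters. In this assay, phenyl in place of 6-hydroxyhex-1-yn-1-yl gives a 22-fold higher number from compound 2 to compound 3 (1.35 log units; beyond the scatter), so the chain is not interchangeable with an aromatic ring here. No evidence at hand explains this difference.

As far as these compounds go, the swap removes the triple bond and the chain's hydroxy group together, so their separate contributions remain unknown. A longer chain, or one ending in an amine or a carboxylic acid, would help separate them.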